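Compound 1 to compound 4: chloro replaced by hydrogen

The source may report more compounds than this note shows. Statements on the series, on what has been measured and on what is new or still open speak of the compounds shown alone.

Compound 1 `COc1ccc(NC(=O)C(=O)c2cn(C(C)C)c3c(Cl)cccc23)cn1` gives in a functional assay on FaDu cells (Homo sapiens) for cytotoxicity, read by MTT assay, with a stated time of 72 h (on this read-out lower numbers stand for higher toxicity in this test and higher numbers for lower toxicity in this test), a value of 10200 nM.
Compound 2 `COc1ccc(NC(=O)C(=O)c2cn(C(C)(C)COCC(=O)O)c3ccccc23)cn1` reaches only the limit of > 10000 nM in this assay.
Compound 3 `COc1ccc2c(c1)c(C(=O)C(=O)Nc1ccc(OC)nc1)cn2C(C)C` likewise sits at the limit of > 10000 nM in this assay.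

Among the three measured compounds, compound 1 is the only one with an actual number in this assay; the other two sit at the limit of > 10000 nM in this assay, at which 2 of the 3 values shown sit. Within the data shown here, no step between measured compounds that differ in one place is available, so nothing yet shows how a single change moves the read-out. Compound 4 `COc1ccc(NC(=O)C(=O)c2cn(C(C)C)c3ccccc23)cn1` differs from compound 1 by hydrogen in place of chloro on an aromatic carbon. Among the measured compounds shown here, with no measured step to lean on, a step of a 1.5-fold higher number from compound 1 to compound 4 (0.17 log units; within the scatter) is expected, small and not clearly beyond the scatter. Compound 4 is estimated at 15000 nM, within a range from 6000 nM to 40000 nM.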

Compound 4, concentration lethal to 50% of the cells: 85 nM
Compound 4: middle estimate off by 180-fold (2.25 log units), on the high side; the measured number lies below the stated range.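

On this aromatic carbon of the shared core, hydrogen in place of chloro gives a 120-fold lower number from compound 1 to compound 4 (2.08 log units; beyond the scatter) in this assay. Hydrogen in place of methoxy on an aromatic carbon gives an at least 110-fold lower number from compound 3 to compound 4 (2.07 log units; beyond the scatter), and hydrogen in place of (carboxymethoxy)methyl on the saturated chain carbon gives an at least 110-fold lower number from compound 2 to compound 4 (2.07 log units; beyond the scatter). These two steps start from limits of the assay, not from numbers: the limit of > 10000 nM in this assay, at which 2 of the 4 values shown sit.

On these data alone, whether fluoro or methyl on that aromatic carbon would keep the low number of compound 4 stays open. The compounds shown also cannot tell why chloro has so large an effect.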